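The compounds below may be only part of what the source reports. "The series", "measured", "known", "first", "only" and "open" are said of these compounds alone.

Among the three measured compounds, compound 3 `c1csc(-c2noc(-c3ccc(C4=NCCN4)cc3)n2)c1` gives the lowest number in an assay for inhibition of Amine oxidase [flavin-containing] A (Homo sapiens), read by fluorescence and spectrophotometry, using microsomes, with stated times of 30 min and 20 min (on this read-out higher numbers stand for weaker inhibition and lower numbers for stronger inhibition), with compound 3 at 1570 nM. Compound 2 `CC(C)c1noc(-c2ccc(C3=NCCN3)cc2)n1` gives 22500 nM, and compound 1 `c1cc(C2=NCCN2)cc(-c2noc(-c3cccs3)n2)c1` gives 88300 nM. Among the measured compounds shown here, the only single-site step recorded is a 14-fold lower number from compound 2 to compound 3 (1.16 log units; beyond the scatter). Compound 4 `Clc1ccccc1-c1noc(-c2ccc(C3=NCCN3)cc2)n1` differs from compound 3 by 2-chlorophenyl in place of thiophen-2-yl on an aromatic carbon. That earlier step bears on it only loosely: it shows that an aromatic ring in this position outperforms isopropyl, while compound 4 keeps an aromatic ring there. For the measured compounds named here, no measured step compares two different aromatic rings at this position, so the expected change from compound 3 to compound 4 is none beyond the scatter, a 1.3-fold higher number from compound 3 to compound 4 (0.11 log units; within the scatter). Compound 4 is therefore estimated at 2000 nM, with a range from 600 nM to 6500 nM.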

Compound 4, half-maximal inhibitory concentration: 17100 nM
Estimate against measurement, compound 4: 8.6-fold (0.93 log units) below; the measured number lies above the stated range.
By their numbers in this assay, from the lowest: compound 3; then compounds 4 and 2 (each within the scatter of the next); then compound 1.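

At this position of the shared core, an aromatic ring alone does not bring the lower number seen with thiophen-2-yl: in this assay the change to 2-chlorophenyl gives an 11-fold higher number from compound 3 to compound 4 (1.04 log units; beyond the scatter) and the isopropyl compound relates to the 2-chlorophenyl compound by a 1.3-fold lower number from compound 2 to compound 4 (0.12 log units; within the scatter) in the same read-out. Among the groups shown at this place, thiophen-2-yl alone stands apart. No evidence here accounts for the gap between the two aromatic rings.

The compounds shown leave open whether the higher number goes with the chlorine or with the six-membered ring, a question that plain phenyl would separate. On these data alone, how furan-2-yl would read at this position also remains open.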